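Swapping isopropyl for trifluoromethylphenyl: what cytotoxicity to expect

This account rests on a few compounds, and the source may have more. Where it says the series, first, only, none or still open, it means among the compounds named here.

Compound 2 `Cc1ccccc1-c1nn(C(C)C)cc1CNCCN1CCN(C)CC1` is one of three compounds tested in an ADME assay on Huh-7 cells (Homo sapiens) for cytotoxicity; a lower number here means that less compound is tolerated, a higher number that more compound is tolerated. In this assay compound 2 gives > 20000 nM, which is a limit of the assay and not a number. Compound 1 `CN1CCN(CCNCc2cn(-c3ccc(F)cc3F)nc2-c2ccc(S(=O)(=O)N(C)C)cc2)CC1` stops at > 20000 nM, again a limit. Compound 3 `CN1CCN(CCNCc2cn(-c3ccc(F)cc3F)nc2C2CCCCC2)CC1` reaches > 20000 nM, also a limit. Within the data shown here, the single measured step, a step that the two limits leave unreadable from compound 1 to compound 3, therefore has no readable size, and the limit of > 20000 nM in this assay, at which 3 of the 3 values shown sit, sums up the evidence. Compound 4 `Cc1ccccc1-c1nn(-c2cccc(C(F)(F)F)c2)cc1CNCCN1CCN(C)CC1` differs from compound 2 by 3-(trifluoromethyl)phenyl in place of isopropyl on an aromatic nitrogen. Among the measured compounds shown here, no measured step bears on this change, so the expectation is a step of none beyond the scatter. Compound 4 is expected to stay at the limit, with an estimated 20000 nM and a range from 8000 nM to 40000 nM. The step of a number no higher from compound 2 to compound 4 (the limit leaves the size open) is thus expected to be flat.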

Compound 4, half-maximal cytotoxic concentration: 18000 nM
For compound 4 the middle estimate is 1.1-fold (0.05 log units) above the measured one, within the range that was stated.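

With 3-(trifluoromethyl)phenyl in place of isopropyl on the aromatic nitrogen, this assay yields its first value that is a number and not a limit, giving an at least 1.1-fold lower number from compound 2 to compound 4 (0.04 log units; that floor lies within the scatter). Only this floor can be read, so the change may be flat or larger, and no other value here helps to size it: the limit of > 20000 nM in this assay, at which 3 of the 4 values shown sit.

Going by these compounds, how far the true value of compound 2 lies past its limit stays open, and with it the full size of this step. Also open, on these data alone, is how an amine, a carboxylic acid or a longer alkyl chain on that nitrogen would read in this assay.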